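Extending the amide tail of a spirocyclic cholesterol-transporter binder

The source may hold more compounds than are shown below. What is called first, only, known or untested is meant among the compounds shown, and "the series" means these compounds.

Of the compounds shown here, two sharing the same core have been measured. Compound 1 `CC(C)(C)OC(=O)NCCNC(=O)CN1CN(c2ccccc2)C2(CCN(C(=O)c3ccc(C4CCCCC4)cc3)CC2)C1=O` gives 5500 nM in an assay on HEK293 cells for displacement of a labelled ligand from NPC1-like intracellular cholesterol transporter 1 (Homo sapiens) (on this read-out higher numbers stand for weaker inhibition and lower numbers for stronger inhibition), and compound 2 `CC(C)(C)c1ccc(C(=O)N2CCC3(CC2)C(=O)N(CC(=O)NCCN)CN3c2ccccc2)cc1` gives 7000 nM in the same assay. Compound 2 stands highest of the two numbers, but its nearest neighbour, compound 1, lies within the scatter of it, so the two cannot be told apart on these data.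

Compound 3 `CC(C)(C)c1ccc(C(=O)N2CCC3(CC2)C(=O)N(CC(=O)NCCCCNS(C)(=O)=O)CN3c2ccccc2)cc1` has not yet been measured. It differs from compound 2 by one change: 2-(methanesulfonamido)ethyl in place of amino on a saturated chain carbon, two bonds along the chain from an amide-type nitrogen. Going by the values given here, no measured pair in this small set isolates a comparable change, so there is nothing to anchor the size or direction of its effect. On that basis compound 3 is expected to show no step beyond the scatter, and the step from compound 2 to compound 3 is estimated as a 1.2-fold lower number from compound 2 to compound 3 (0.07 log units; within the scatter). Compound 3 is therefore estimated at 6000 nM, with a range from 2000 nM to 20000 nM.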

Compound 3, half-maximal inhibitory concentration: 4500 nM
The estimate for compound 3 lay 1.3-fold (0.12 log units) above the measured number, within the range that was stated.
By their numbers in this assay, from the lowest: compounds 3, 1 and 2 (each within the scatter of the next).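

Going by these compounds alone, this is the first pair in the set that differs in one place, and it gives a reading on the chain end itself. Putting 2-(methanesulfonamido)ethyl in place of amino, on a saturated chain carbon two bonds along the chain from an amide-type nitrogen, gives a 1.6-fold lower number from compound 2 to compound 3 (0.19 log units; within the scatter) in this assay, so a group of seven heavy atoms takes the place of a single nitrogen without a step that can be told from the scatter. No separate measurement bears on why the number stays put at this position.

Going by these compounds, whether a carboxylic acid, a tertiary amine or an aromatic ring at this chain end would shift the number beyond the scatter remains open. So does the effect of a shorter chain carrying the same methanesulfonamide, which would separate chain length from the end group.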